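The source may hold more compounds than are shown below. What is called first, only, known or untested is meant among the compounds shown, and "the series" means these compounds.

Among the compounds with values here, in a functional assay on DU-145 cells (Homo sapiens) for antiproliferative activity, read by propidium iodide staining, with a stated time of 96 h (on this read-out lower numbers stand for stronger inhibition and higher numbers for weaker inhibition), compound 1 `CC(O)(CSc1cccc(S(F)(F)(F)(F)F)c1)C(=O)Nc1ccc(S(F)(F)(F)(F)F)cc1` gives 17300 nM and compound 2 `CC(O)(CSc1cccc(C(F)(F)F)c1)C(=O)Nc1ccc(S(F)(F)(F)(F)F)cc1` gives 26200 nM, so compound 2 stands within the scatter of its only measured neighbour. Compound 3 `CC(O)(CSc1cccc(OC(F)(F)F)c1)C(=O)Nc1ccc(S(F)(F)(F)(F)F)cc1` has trifluoromethoxy in place of trifluoromethyl on an aromatic carbon. Within the data shown here, the one measured step, a 1.5-fold higher number from compound 1 to compound 2 (0.18 log units; within the scatter), also exchanged a fluorine-bearing group on an aromatic carbon, and it stayed within the scatter. No step beyond the scatter is therefore expected in this assay, although a single step is thin evidence. The estimated step is a 1.2-fold lower number from compound 2 to compound 3 (0.08 log units; within the scatter). For compound 3 the expected value is 22000 nM, with a range of 11000 nM to 42000 nM.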

Compound 3, half-maximal inhibitory concentration: 23800 nM
Compound 3: middle estimate off by 1.1-fold (0.03 log units), on the low side, and the stated range covers the measured number.
By their numbers in this assay, from the lowest: compounds 1, 3 and 2 (each within the scatter of the next).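

In this assay, trifluoromethoxy in place of trifluoromethyl on this aromatic carbon gives a 1.1-fold lower number from compound 2 to compound 3 (0.04 log units; within the scatter), and the same group in place of the group of sulfur and five fluorines gives a 1.4-fold higher number from compound 1 to compound 3 (0.14 log units; within the scatter). So a group with one hydrogen-bond acceptor, where the earlier two groups at this position have none, still separates none of the three compounds. No accompanying measurement bears on why these numbers lie so close together. On these data alone, all three groups carry fluorine, so it remains open whether an amine or a carboxylic acid here would give a step beyond the scatter.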